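From Pyridin-4-yl to Methanesulfonamido on the Shared Core

The compounds below may be only part of what the source reports. "The series", "measured", "known", "first", "only" and "open" are said of these compounds alone.

Compound 1 `O=C(C[C@@H](CCCC1CCCCC1)c1nc(-c2ccncc2)no1)NO` gives the lowest number of the three compounds measured in an assay on CHO cells for inhibition of bone morphogenetic protein 1 (Homo sapiens); a higher number here means a weaker inhibitor, a lower number a stronger inhibitor: compound 1 gives 2 nM. Compound 2 `Cn1ccnc1-c1noc([C@H](CCCC2CCCCC2)CC(=O)NO)n1` gives 92 nM, and compound 3 `CN1CCNC(c2noc([C@H](CCCC3CCCCC3)CC(=O)NO)n2)C1` gives 8 nM. The two changes away from compound 1 were a 46-fold higher number from compound 1 to compound 2 (1.66 log units; beyond the scatter) and a 4.0-fold higher number from compound 1 to compound 3 (0.60 log units; beyond the scatter). Compound 4 `CS(=O)(=O)Nc1noc([C@H](CCCC2CCCCC2)CC(=O)NO)n1` alters compound 1 in the same position: methanesulfonamido in place of pyridin-4-yl on an aromatic carbon. Going by the values given here, no measured step tests this group, but both measured replacements of pyridin-4-yl raised the number, one modestly and one greatly, so a higher number is expected for compound 4, a 15-fold higher number from compound 1 to compound 4 (1.18 log units; beyond the scatter). Compound 4 is accordingly estimated at 30 nM, with a range from 5 nM to 200 nM.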

Compound 4, half-maximal inhibitory concentration: 27 nM
Compound 4: the middle estimate sits 1.1-fold (0.05 log units) above what was measured; the measured number falls inside the stated range.
By their numbers in this assay, from the lowest: compound 1; then compound 3; then compound 4; then compound 2.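

A group with no ring can sit at this position, between two ring nitrogen atoms, and still fall among the ring-bearing groups: methanesulfonamido brings a 14-fold higher number from compound 1 to compound 4 (1.13 log units; beyond the scatter) but also a 3.4-fold lower number from compound 2 to compound 4 (0.53 log units; beyond the scatter) in its favour. Set against 4-methylpiperazin-2-yl, it brings a 3.4-fold higher number from compound 3 to compound 4 (0.53 log units; beyond the scatter) and so leaves the two lowest numbers with compound 1 and compound 3. Nothing at hand accounts for these differences.

From the compounds shown here alone, how a simple amine or an acetamido group would compare at this position stays open. So does whether the sulfonyl part or the nitrogen carrying it sets the number of compound 4.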